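The source may hold more compounds than are shown below. What is called first, only, known or untested is meant among the compounds shown, and "the series" means these compounds.

In a functional assay on MGC-803 cells (Homo sapiens) for antiproliferative activity, read by MTT assay (a higher number here means a weaker inhibitor, a lower number a stronger inhibitor), compound 1 `Cc1ccccc1NC(=O)Nc1cccc(CNc2ncnc3ccccc23)c1` reaches only the limit of the assay, > 50000 nM. Within the data shown here, compound 2 `COc1cc2ncnc(NCc3cccc(NC(=O)Nc4cccc(C)c4)c3)c2cc1OC` gives 44600 nM in this assay, the one number among the two values shown. Across those two values, compound 1 alone sits at the limit of > 50000 nM in this assay, at which 1 of the 2 values shown sits. Compound 3 `COc1cc2ncnc(NCc3cccc(NC(=O)Nc4ccc([N+](=O)[O-])cc4)c3)c2cc1OC` carries a single change from compound 2: 4-nitrophenyl in place of 3-methylphenyl on an amide-type nitrogen. No measured step of this kind is shown, so the change is expected to move this assay by no more than the usual scatter, in no set direction. Compound 3 is therefore estimated at 35000 nM, within 10000 nM to 120000 nM. That estimate means an expected step of a 1.3-fold lower number from compound 2 to compound 3 (0.11 log units; within the scatter), inside the scatter.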

Compound 3, half-maximal inhibitory concentration: 8120 nM
Compound 3: middle estimate off by 4.3-fold (0.63 log units), on the high side; the measured number lies below the stated range.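

In this assay, among these compounds, 4-nitrophenyl in place of 3-methylphenyl on an amide-type nitrogen gives the first readable step at this position: a 5.5-fold lower number from compound 2 to compound 3 (0.74 log units; beyond the scatter). The group on this nitrogen can therefore move the read-out beyond the scatter, which compounds 1 and 2 alone could not show, as they differ in more than one place. No measured property shown here accounts for this step. The compounds shown do not separate the nitro group from its place on the ring. From the compounds shown here alone, how a 4-aminophenyl or 4-carboxyphenyl group would read on the same nitrogen also stays open.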